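The source may report more compounds than this note shows. Statements on the series, on what has been measured and on what is new or still open speak of the compounds shown alone.

Going by the values given here, compound 2 `Cc1ccc(C(c2c[nH]c3ccc(I)cc23)c2c[nH]c3ccc(I)cc23)cc1` gives 22600000 nM in a functional assay on ME18 cells (Homo sapiens) for cytotoxicity, read by MTT assay, with a stated time of 48 h (a lower number here means a stronger inhibitor, a higher number a weaker inhibitor), the highest of the two numbers so far, while compound 1 `Ic1ccc2[nH]cc(Cc3c[nH]c4ccc(I)cc34)c2c1` gives 9700000 nM. Among the compounds with values here, the single measured step, a 2.3-fold higher number from compound 1 to compound 2 (0.37 log units; beyond the scatter), adds a whole 4-methylphenyl group to the chain carbon. Compound 3 `Fc1cc(F)cc(C(c2c[nH]c3ccc(I)cc23)c2c[nH]c3ccc(I)cc23)c1` changes that same carbon differently: 3,5-difluorophenyl in place of 4-methylphenyl on a saturated chain carbon bound to two aromatic carbons. Within the data shown here, no measured step exchanges one six-membered aromatic ring of carbon only for another. The step to compound 3 is therefore expected to stay within the usual scatter, a 1.1-fold lower number from compound 2 to compound 3 (0.05 log units; within the scatter). Compound 3 is estimated at 20000000 nM, with a range from 7000000 nM to 60000000 nM.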

Compound 3, half-maximal inhibitory concentration: 21300000 nM
Compound 3: middle estimate off by 1.1-fold (0.03 log units), on the low side, within the range that was stated.
By their numbers in this assay, from the lowest: compound 1; then compounds 3 and 2 (each within the scatter of the next).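

Replacing 4-methylphenyl with 3,5-difluorophenyl on the saturated chain carbon gives a 1.1-fold lower number from compound 2 to compound 3 (0.03 log units; within the scatter) in this assay, so these two aromatic groups cannot be told apart at this position. Compared with hydrogen, 3,5-difluorophenyl gives a 2.2-fold higher number from compound 1 to compound 3 (0.34 log units; beyond the scatter) and so moves the number the same way as 4-methylphenyl, with neither compound going against this. Nothing shown here explains these results.

Going by these compounds, whether this holds for a group without an aromatic ring on this carbon, such as an amine, a carboxylic acid or a longer chain, remains open.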